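The source may report more compounds than this note shows. Statements on the series, on what has been measured and on what is new or still open speak of the compounds shown alone.

Compound 1 `O=C(/C=C/c1ccc2c(c1)B(O)OC2)c1ccc(-c2ccccc2)cc1` gives in a functional assay on MDA-MB-231 cells (Homo sapiens) for cytotoxicity, read by MTT assay, with a stated time of 48 h (on this read-out higher numbers stand for weaker inhibition and lower numbers for stronger inhibition), 6400 nM.
Compound 2 `Cn1cccc1C(=O)/C=C/c1ccc2c(c1)B(O)OC2` gives in this assay a limit of the assay, > 100000 nM.
Compound 3 `O=C(/C=C/c1ccc2c(c1)B(O)OC2)c1ccc(Br)cc1` gives in this assay 9500 nM.

Compound 3 has the higher of the two numbers recorded, but its nearest neighbour is compound 1, and the step of a 1.5-fold higher number from compound 1 to compound 3 (0.17 log units; within the scatter) lies within the scatter, so the two are not distinguishable on these data. Compound 2 sits at the assay's upper limit, (the limit of > 100000 nM in this assay, at which 1 of the 3 values shown sits), and the step of an at least 10-fold lower number from compound 2 to compound 3 (1.02 log units; beyond the scatter) is large.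

Compound 4 `O=C(/C=C/c1ccc2c(c1)B(O)OC2)c1ccc([N+](=O)[O-])cc1` differs from compound 3 in one place: nitro in place of bromo on an aromatic carbon. Among the measured compounds shown here, the step that most resembles this change is the one from compound 1 to compound 3, where the same aromatic carbon carried a different group and the number barely moved. The large step from compound 2 to compound 3 concerns a different part of the molecule, the group on the carbonyl carbon, and bears only loosely on swapping one substituent on the aromatic ring for another.

On this basis no step beyond the scatter is expected in this assay for compound 4, with a wide margin allowed for the untested nitro group; the expected step is a 1.3-fold higher number from compound 3 to compound 4 (0.10 log units; within the scatter). Compound 4 is therefore estimated at 12000 nM, within a range of 4000 nM to 40000 nM.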

Compound 4, half-maximal inhibitory concentration: 11200 nM
Estimate against measurement, compound 4: 1.1-fold (0.03 log units) above; the range from low to high includes it.
By their numbers in this assay, from the lowest: compounds 1, 3 and 4 (each within the scatter of the next). At a limit, above all of these: compound 2.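

In this assay, the aromatic carbon para to a large group has now carried three different groups, and nitro in place of bromo gives a 1.2-fold higher number from compound 3 to compound 4 (0.07 log units; within the scatter), while nitro in place of phenyl gives a 1.8-fold higher number from compound 1 to compound 4 (0.24 log units; within the scatter). The earlier compounds shown here showed only phenyl and bromo at this position, whereas compound 4 brings nitrogen and oxygen atoms and hydrogen-bond acceptors, which bromo lacks, and its number still cannot be told apart from those of compound 1 and compound 3. Across these three compounds, the choice of group at this carbon makes no readable difference, and nothing shown gives a cause for that.

On these data alone, an amine or a carboxylic acid on this same carbon remains open, as does a plain hydrogen there, so it is unknown whether any group at this position can move the number beyond the scatter. Also open, as far as these compounds go, is whether such swaps would leave the number just as steady with a different ring on the carbonyl carbon, as compound 2 alone carries another ring there.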